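The source may report more compounds than this note shows. Statements on the series, on what has been measured and on what is new or still open speak of the compounds shown alone.

In an ADME assay on NIH3T3 cells (Mus musculus) for cytotoxicity, read by LDH release, with a stated time of 48 h (on this read-out lower numbers stand for stronger inhibition and higher numbers for weaker inhibition), compound 1 `Cn1cnc(C(=O)NNC(=O)COc2c(F)cc(C(=O)c3ccc(F)cc3)cc2Cl)c1` gives 94400 nM. Among the three measured compounds this is the second highest number. Compound 2 `Cn1cnc(C(=O)NNC(=O)COc2ccc(C(=O)c3ccccc3)cc2)c1` gives 97400 nM, which lies within the scatter of compound 1, so the two cannot be told apart. Compound 3 `Cc1ccc(C(=O)c2cc(F)c(OCC(=O)NNC(=O)c3ccc(=O)oc3)c(Cl)c2)cc1` gives 32100 nM, a lower number beyond the scatter. Compound 4 `Cc1ccc(C(=O)c2cc(F)c(OCC(=O)NNC(=O)c3cn(C)cn3)c(Cl)c2)cc1` differs from compound 1 in one place: methyl in place of fluoro on an aromatic carbon. Going by the values given here, compound 3 also carries a 4-methylphenyl group, but it differs from compound 4 elsewhere as well, so no single step in this assay isolates this change. The step from compound 1 to compound 4 is expected to be small, a 1.3-fold lower number from compound 1 to compound 4 (0.13 log units; within the scatter), and compound 4 is estimated to give 70000 nM, within 30000 nM to 160000 nM.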

Compound 4, half-maximal inhibitory concentration: 94900 nM
Compound 4: the middle estimate sits 1.4-fold (0.13 log units) below what was measured; low and high end bracket the measured number.
By their numbers in this assay, from the lowest: compound 3; then compounds 1, 4 and 2 (each within the scatter of the next).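

In this assay, 4-methylphenyl in place of 4-fluorophenyl gives a 1.0-fold higher number from compound 1 to compound 4 (0.00 log units; within the scatter) and so leaves the number unchanged within the scatter, which shows that this read-out does not separate these two groups at this position. A change elsewhere does register: with 4-methylphenyl held fixed, the five-membered aromatic ring group in place of the six-membered one on the carbonyl carbon gives a 3.0-fold higher number from compound 3 to compound 4 (0.47 log units; beyond the scatter) as a modest step. Nothing measured here explains either result. Still open, from the compounds shown here alone, is whether an amine or a carboxylic acid in place of the methyl would also leave the number unchanged, and whether the step at the carbonyl carbon holds with 4-fluorophenyl present.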